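Tolerance notes: methoxy to dimethylamino on compound 2

This account rests on a few compounds, and the source may have more. Where it says the series, first, only, none or still open, it means among the compounds named here.

Compound 1 `CCC(=O)Nc1cc(C(=O)Nc2ccc(N3CCN(C)CC3)cc2)ccc1OC` reads > 200000 nM in a toxicity assay on Huh-7.5 cells (Homo sapiens) for inhibition, read by MTT assay, with a stated time of 96 h (a higher number here means that more compound is tolerated, a lower number that less compound is tolerated), and this is a limit of the assay, not a number. Among the compounds with values here, compound 2 `CCC(=O)Nc1cc(C(=O)Nc2ccc(OC)cc2)ccc1OC` gives 109000 nM in this assay, the only true number so far, so it can be ranked against no other measured value. Compound 3 `CCC(=O)Nc1cc(C(=O)Nc2ccc(N(C)C)cc2)ccc1OC` has dimethylamino in place of methoxy on an aromatic carbon, para to a large group (dimethylamino in place of methoxy on an aromatic carbon). Within the data shown here, only one measured step bears on this change: an at least 1.8-fold lower number from compound 1 to compound 2 (0.26 log units; that floor lies within the scatter). From the compounds shown here alone, that step replaces 4-methylpiperazin-1-yl with methoxy at the same place, and since it rests on a limit, its true size is unknown. Its floor gives no evidence of a large effect at this place, but it sets no ceiling either. No step beyond the scatter is therefore expected in this assay, with a slight lean towards a higher number, as compound 1 gives > 200000 nM. The estimate amounts to a 1.1-fold higher number from compound 2 to compound 3 (0.04 log units; within the scatter), an expected change within the scatter. For compound 3 the expected value is 120000 nM, with an estimated range of 60000 nM to 200000 nM.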

Compound 3, half-maximal cytotoxic concentration: 171000 nM
The estimate for compound 3 lay 1.4-fold (0.15 log units) below the measured number; low and high end bracket the measured number.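

In this assay, dimethylamino in place of methoxy on an aromatic carbon, para to a large group, gives a 1.6-fold higher number from compound 2 to compound 3 (0.20 log units; within the scatter). Within the data shown here, this is the first step between two true numbers, and it shows that this exchange of one small group for another does not move the tolerated concentration beyond the scatter in this assay. The step with 4-methylpiperazin-1-yl as its starting point reads an at least 1.1-fold lower number from compound 1 to compound 3 (0.06 log units; that floor lies within the scatter), which is only a floor, so the true size of that change stays unknown, and the reading for compound 1 is a limit, not a number: the limit of > 200000 nM in this assay, at which 1 of the 3 values shown sits.

Among these compounds, whether any group at this place can shift the number beyond the scatter remains open, since the comparisons with the one large ring substituent rest on a limit and the only step between true numbers is small. A primary amine, a carboxylic acid or a longer alkoxy chain on the same aromatic carbon would test whether this place tolerates change as broadly as the two small groups suggest.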